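A few compounds are considered here, and "the series" means these few. Any claim that something is new, unique, unknown or untested is made for them only; others in the source may bear on it.

Measured so far in an ADME assay on Huh-7 cells (Homo sapiens) for cytotoxicity, read by XTT assay, with a stated time of 3 days, tested at 20 uM; a lower number here means a stronger effect, a higher number a weaker effect of the compound at the concentration tested:
compound 1 `Fc1ccc(-c2cc(-c3ccc4cc(F)ccc4n3)n(-c3ccc(F)cc3)n2)cc1` gives 95.3%
compound 2 `COc1ccc(-c2cc(-c3ccc4cc(F)ccc4n3)n(-c3ccc(F)cc3)n2)cc1` gives 98.8%

Compound 2 stands highest of the two numbers, with compound 1 nearest at a number 3.5 percentage points higher from compound 1 to compound 2 (within the scatter), so the two cannot be told apart. Compound 3 `COc1ccc(-c2cc(-c3ccc4cc(F)ccc4n3)n(-c3ccc(S(N)(=O)=O)cc3)n2)cc1` is not yet measured; it differs from compound 2 by sulfamoyl in place of fluoro on an aromatic carbon. Among the compounds with values here, no measured step touches the 4-fluorophenyl group, and the single step known in this assay lies within the scatter, so nothing argues for a change beyond it. Compound 3 is therefore expected to give about 96%, between 84% and 104%, a step of a number 2.8 percentage points lower from compound 2 to compound 3 (within the scatter) that is itself expected to stay within the scatter.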

Compound 3, a percentage reported as activity, at one concentration (the size of the read-out at that concentration, not a potency): 83.7%
Compound 3: the middle estimate sits 12.3 percentage points above what was measured; measured number outside the range, below it.
By their numbers in this assay, from the lowest: compound 3; then compounds 1 and 2 (each within the scatter of the next).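

Within the data shown here, exchanging 4-fluorophenyl for 4-sulfamoylphenyl gives the first change in this assay that exceeds the scatter: a number 15.1 percentage points lower from compound 2 to compound 3 (beyond the scatter). This position therefore responds to substitution, and the step is modest; the earlier methoxy-for-fluoro change elsewhere on the core gave only a number 3.5 percentage points higher from compound 1 to compound 2 (within the scatter). No measurement available here accounts for the step. As far as these compounds go, whether an amine, a carboxylic acid or a methyl sulfone at this place would give a similar step remains open. Also open, from the compounds shown here alone, is whether sulfamoyl would give the same step on the core of compound 1.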